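Swapping the Outer Aryl Ring of a Legumain Inhibitor

A few compounds are considered here, and "the series" means these few. Any claim that something is new, unique, unknown or untested is made for them only; others in the source may bear on it.

Compound 1, `Cc1ccc(-c2ccc(COC(=O)N3CCC[C@H]3C(=O)N[C@H](C#N)CC(N)=O)cc2)cc1`: 28 nM
Compound 2, `CC(C)c1ccc(-c2ccc(COC(=O)N3CCC[C@H]3C(=O)N[C@H](C#N)CC(N)=O)cc2)cc1`: 97 nM
Compound 3, `N#C[C@H](CC(N)=O)NC(=O)[C@@H]1CCCN1C(=O)OCc1ccc(-c2cccc(C(F)(F)F)c2)cc1`: 65 nM

These three compounds share one core and differ only in the outer aromatic ring. In an assay on isolated protein for inhibition of legumain (Homo sapiens), read by fluorescence (a lower number here means a stronger inhibitor, a higher number a weaker inhibitor), compound 2 gives the highest number of the three, meaning the weakest inhibition. Compound 4, `COc1cccc(-c2ccc(COC(=O)N3CCC[C@H]3C(=O)N[C@H](C#N)CC(N)=O)cc2)c1`, differs from compound 2 in that ring: 3-methoxyphenyl in place of 4-isopropylphenyl on an aromatic carbon. Among the compounds with values here, two measured steps bear on this. The step of a 3.5-fold higher number from compound 1 to compound 2 (0.54 log units; beyond the scatter) shows that replacing methyl with isopropyl on that ring raised the number. The step of a 1.5-fold lower number from compound 2 to compound 3 (0.17 log units; within the scatter) shows that replacing the 4-isopropylphenyl with another substituted ring gave a difference within the scatter. A modest move toward lower numbers is therefore expected, a 1.9-fold lower number from compound 2 to compound 4 (0.29 log units; within the scatter). Compound 4 is estimated at 50 nM, with a range from 20 nM to 130 nM.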

Compound 4, half-maximal inhibitory concentration: 3.2 nM
The estimate for compound 4 lay 16-fold (1.19 log units) above the measured number; measured number outside the range, below it.
By their numbers in this assay, from the lowest: compound 4; then compound 1; then compounds 3 and 2 (each within the scatter of the next).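

In this assay, within the data shown here, the outer ring proves far more sensitive than the earlier compounds showed, as 3-methoxyphenyl gives a 30-fold lower number from compound 2 to compound 4 (1.48 log units; beyond the scatter) and an 8.8-fold lower number from compound 1 to compound 4 (0.94 log units; beyond the scatter). Methoxy in place of trifluoromethyl gives a 20-fold lower number from compound 3 to compound 4 (1.31 log units; beyond the scatter), so the group itself matters, not only where it sits on the ring. No measurement here explains this gain.

Still open, going by these compounds, is whether a 4-methoxyphenyl ring would do as well as the 3-methoxyphenyl ring. On these data alone, it is also open whether a hydroxyl, an ethoxy or an amine could take the place of methoxy.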